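From benzyl to isopentyl: compound 3 to compound 4

The compounds below may be only part of what the source reports. "The series", "measured", "known", "first", "only" and "open" are said of these compounds alone.

Measured in an ADME assay on 2209-23 cells (Homo sapiens) for cytotoxicity, read by WST assay and thymidine incorporation; on this read-out lower numbers stand for higher toxicity in this test and higher numbers for lower toxicity in this test:
Compound 1 `CC(C)(C)CCN1C(=O)C(C2=CS(=O)(=O)c3cc(NS(C)(=O)=O)ccc3N2)=C(O)[C@@H]1C(C)(C)C`: > 50000 nM
Compound 2 `CC(C)(C)[C@H]1C(O)=C(C2=CS(=O)(=O)c3cc(NS(C)(=O)=O)ccc3N2)C(=O)N1Cc1ccc(F)cc1F`: > 50000 nM
Compound 3 `CC(C)(C)[C@H]1C(O)=C(C2=CS(=O)(=O)c3cc(NS(C)(=O)=O)ccc3N2)C(=O)N1Cc1ccccc1`: > 50000 nM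

These entries are limits, not numbers: the limit of > 50000 nM in this assay, at which 3 of the 3 values shown sit. Compound 3 gives > 50000 nM, which is a limit, so no order among the three can be read.

Compound 4 `CC(C)CCN1C(=O)C(C2=CS(=O)(=O)c3cc(NS(C)(=O)=O)ccc3N2)=C(O)[C@@H]1C(C)(C)C` differs from compound 3 at one place: isobutyl in place of phenyl on a saturated chain carbon bound to an amide-type nitrogen in a ring. Two measured steps change that same place: a step that the two limits leave unreadable from compound 1 to compound 3 and a step that the two limits leave unreadable from compound 2 to compound 3. Neither has a readable size, but none of the three groups tried there brought a number into this assay, so no step beyond the scatter is expected. The expected change is a step that the limit leaves unreadable from compound 3 to compound 4. Compound 4 is estimated at 60000 nM, with an expected range of 30000 nM to 120000 nM, and will probably be reported as a limit again.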

Compound 4, half-maximal cytotoxic concentration: > 50000 nM
Compound 4 was reported as a limit; the forecaster's own chance of this, stated with the estimate: 90%; the middle value is on the limit's open side.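

Within the data shown here, compound 4, like compound 1, compound 2 and compound 3, gives only a limit, so no step among the four can be read: the limit of > 50000 nM in this assay, at which 4 of the 4 values shown sit.

Left open is whether the four differ at all in this assay and at what concentration each would harm the cells.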